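The compounds below may be only part of what the source reports. "The series", "measured", "known", "first", "only" and "open" are said of these compounds alone.

Compound 1 `COc1ccc2c(c1)c(-c1nc3ccccc3n1C(=O)c1ccc(OC)c(OC)c1)cn2C` gives 6300 nM in a functional assay on MCF7 cells (Homo sapiens) for inhibition, read by MTT assay, with a stated time of 24 h; a higher number here means a weaker inhibitor of growth, a lower number a stronger inhibitor of growth.
Compound 2 `COc1ccc2c(c1)c(-c1nc3ccccc3n1C(=O)c1ccccc1Br)cn2C` gives 55800 nM in this assay.
Compound 3 `COc1ccc(C(=O)n2c(-c3cn(C)c4ccc(Br)cc34)nc3ccccc32)cc1OC` gives 11300 nM in this assay.

Compound 4 `Cn1cc(-c2nc3ccccc3n2C(=O)c2ccccc2Br)c2cc(Br)ccc21` has not yet been measured in this assay. It stands to compound 3 as compound 2 stands to compound 1: the change is 2-bromophenyl in place of 3,4-dimethoxyphenyl on a carbonyl carbon, and the same change, (2-bromophenyl in place of 3,4-dimethoxyphenyl on a carbonyl carbon), produced the step of an 8.9-fold higher number from compound 1 to compound 2 (0.95 log units; beyond the scatter). The two cores differ by bromo in place of methoxy on an aromatic carbon, which gave only a 1.8-fold higher number from compound 1 to compound 3 (0.25 log units; within the scatter). The place of the change is the same in both pairs, word for word, so this is the same change, seen once before among the measured compounds. For compound 4 a step close to the earlier one is expected, an 8.8-fold higher number from compound 3 to compound 4 (0.95 log units; beyond the scatter), because the measured pair showed an 8.9-fold higher number from compound 1 to compound 2 (0.95 log units; beyond the scatter) and nothing else here suggests otherwise. The estimate for compound 4 is 100000 nM, between 35000 nM and 300000 nM.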

Compound 4, concentration for 50% growth inhibition: 73600 nM
For compound 4 the middle estimate is 1.4-fold (0.13 log units) above the measured one, within the range that was stated.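

Placing 2-bromophenyl in place of 3,4-dimethoxyphenyl on the carbonyl carbon gave a 6.5-fold higher number from compound 3 to compound 4 (0.81 log units; beyond the scatter) in this assay, and the step carried from one core to the other: the same change on two cores in this assay, an 8.9-fold higher number (0.95 log units; beyond the scatter) from compound 1 to compound 2 and a 6.5-fold higher number (0.81 log units; beyond the scatter) from compound 3 to compound 4, 1.4-fold (0.13 log units) apart, within the scatter of two such steps. Bromo in place of methoxy on an aromatic carbon gave a 1.3-fold higher number from compound 2 to compound 4 (0.12 log units; within the scatter), and this smaller step also held: the same change on two cores in this assay, a 1.8-fold higher number (0.25 log units; within the scatter) from compound 1 to compound 3 and a 1.3-fold higher number (0.12 log units; within the scatter) from compound 2 to compound 4, 1.4-fold (0.13 log units) apart, within the scatter of two such steps. Among the compounds shown here, these results cover only two cores and one pair of groups in a single assay, so they do not show that either change would carry to other cores or other groups, nor do they give a reason for the size of either step.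

The compounds shown leave open how an amine or a carboxylic acid on the carbonyl carbon would behave. They also leave open whether a longer chain in place of the methoxy or bromo would fit the same pattern.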